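This account rests on a few compounds, and the source may have more. Where it says the series, first, only, none or still open, it means among the compounds named here.

Four compounds share one core and differ at only two points: the halogen on the outer phenyl ring and the substituent on the ring nitrogen of the core. Compound 1 `O=C(Nc1ccc(Oc2ccnc3[nH]ccc23)cc1)c1nn(-c2ccc(Cl)cc2)ccc1=O` carries a chloro group and a free ring nitrogen; in a functional assay on PC-3 cells (Homo sapiens) for cytotoxicity, read by MTT assay, with a stated time of 72 h (on this read-out lower numbers stand for stronger inhibition and higher numbers for weaker inhibition), compound 1 gives 32400 nM. Compound 2 `O=C(Nc1ccc(Oc2ccnc3[nH]ccc23)cc1)c1nn(-c2ccc(Br)cc2)ccc1=O` carries bromo instead, and in this assay compound 2 gives 8040 nM, a step of a 4.0-fold lower number from compound 1 to compound 2 (0.61 log units; beyond the scatter). Compound 3 `Cn1ccc2c(Oc3ccc(NC(=O)c4nn(-c5ccc(Cl)cc5)ccc4=O)cc3)ccnc21` keeps the chloro group and adds a methyl on the ring nitrogen. For compound 3 the assay reports only a limit, > 60000 nM, (the limit of > 60000 nM in this assay, at which 1 of the 3 values shown sits). So compound 3 stands at the edge of what was resolved, and its step from compound 1 is an at least 1.8-fold higher number from compound 1 to compound 3 (0.26 log units; that floor lies within the scatter), a floor that is not itself a measured size.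

Compound 4 `Cn1ccc2c(Oc3ccc(NC(=O)c4nn(-c5ccc(Br)cc5)ccc4=O)cc3)ccnc21` differs from compound 3 by bromo in place of chloro on an aromatic carbon. Within the data shown here, the one measured step of this kind, from compound 1 to compound 2, lowered the number clearly. The same move is therefore expected to lower the number here too, roughly an at least 3.0-fold lower number from compound 3 to compound 4 (0.47 log units; beyond the scatter), though the starting point is only a limit. Compound 4 is estimated at 20000 nM, within a range from 7000 nM to 65000 nM.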

Compound 4, half-maximal inhibitory concentration: 23000 nM
Compound 4: the middle estimate sits 1.2-fold (0.06 log units) below what was measured; low and high end bracket the measured number.
By their numbers in this assay, from the lowest: compound 2; then compounds 4 and 1 (each within the scatter of the next). At a limit, above all of these: compound 3.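

In this assay the change from 4-chlorophenyl to 4-bromophenyl lowers the number on a second core as well, with an at least 2.6-fold lower number from compound 3 to compound 4 (0.41 log units; beyond the scatter), so the effect seen with the free ring nitrogen also appears when that nitrogen carries a methyl: the same change on two cores in this assay, a 4.0-fold lower number (0.61 log units; beyond the scatter) from compound 1 to compound 2 and an at least 2.6-fold lower number (0.41 log units; beyond the scatter) from compound 3 to compound 4; the limit leaves it open whether they differ

The methyl on the ring nitrogen now also has a step measured at both ends, a 2.9-fold higher number from compound 2 to compound 4 (0.46 log units; beyond the scatter), and this step raises the number beyond the scatter, while the earlier floor for the same change lay within it: the same change on two cores in this assay, an at least 1.8-fold higher number (0.26 log units; that floor lies within the scatter) from compound 1 to compound 3 and a 2.9-fold higher number (0.46 log units; beyond the scatter) from compound 2 to compound 4; the limit leaves it open whether they differ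

Compound 3 gives > 60000 nM, which is a limit of the assay and not a number, so neither step that touches compound 3 has an exact size.

The compounds shown therefore leave open whether the bromo change or the methyl change has the same size on both cores. On these data alone, they also cover only chloro and bromo on the outer phenyl ring and only hydrogen and methyl on the ring nitrogen, so it remains open what an iodo group on that ring, or an ethyl group or a longer chain ending in an amine on that nitrogen, would do.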